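A four-membered ring gives way on compound 1

The source may hold more compounds than are shown below. What is called first, only, known or untested is meant among the compounds shown, and "the series" means these compounds.

In an ADME assay on microsomes from liver (Homo sapiens) for metabolic stability (a lower number here means that the compound disappears faster, a higher number that the compound lasts longer), compound 1 `CC1(C(=O)NCCSc2nonc2/C(=N/O)Nc2ccc(F)c(C(F)F)c2)CCN1` gives 1.97 h. Compound 2 `N#Cc1cccc(N/C(=N\O)c2nonc2SCCNC(=O)CS(N)(=O)=O)c1` gives > 3 h, which is a limit of the assay. For the measured compounds named here, compound 1 therefore holds the only exact number so far.

Compound 3 `CS(=O)(=O)CC(=O)NCCSc1nonc1/C(=N/O)Nc1ccc(F)c(C(F)F)c1` keeps the core of compound 1 and changes one group on a carbonyl carbon: a group of 5 heavy atoms (2 carbon, 2 oxygen, 1 sulfur; no ring) in place of a group of 5 heavy atoms (4 carbon, 1 nitrogen; one four-membered non-aromatic ring with 1 hetero atom), on a carbonyl carbon. In words, (methylsulfonyl)methyl takes the place of a group holding a four-membered non-aromatic ring. Going by the values given here, no step between measured compounds is available to size this swap, so the expectation in this assay is only a modest rise, and a result with no real change would be no surprise. That expectation starts from compound 1 at 1.97 h. The expected change is a 1.3-fold higher number from compound 1 to compound 3 (0.10 log units; within the scatter). For compound 3 the estimate is 2.5 h, with an expected range of 1.3 h to 4.5 h.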

Compound 3, half-life: 1.27 h
Beside the measured number, compound 3's estimate is 2.0-fold (0.29 log units) above it, outside the stated range (below it).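

In this assay, for the compounds shown here, replacing the group that holds a four-membered non-aromatic ring with (methylsulfonyl)methyl, on a carbonyl carbon whose other neighbour is an amide-type nitrogen, gives a 1.6-fold lower number from compound 1 to compound 3 (0.19 log units; within the scatter), and this is the first step that can be read. In this one pair, then, a group with no ring and no hydrogen-bond donor can stand at this place without a shift beyond the usual scatter, so the four-membered ring is not required for a half-life of this order. No measurement shown gives a reason for this step.

From the compounds shown here alone, whether an amine, a carboxylic acid or a longer chain on this carbonyl carbon would also stay within the scatter remains open. This pair also says nothing about changes elsewhere on the shared core.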